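Hydroxy analogue of compound 2 in the cell series

The source may report more compounds than this note shows. Statements on the series, on what has been measured and on what is new or still open speak of the compounds shown alone.

Three members of the series have been measured in a functional assay on SF-295 cells (Homo sapiens) for inhibition, read by sulforhodamine B assay, with a stated time of 48 h; a lower number here means that less compound is tolerated, a higher number that more compound is tolerated. Compound 1 `COc1cc(C)cc(-c2c(-c3ccnc(-c4ccc(N(C)C)cc4)c3)cnn2CC#N)c1` gives only a limit in this assay, > 100000 nM. Compound 2 `COc1cc(C)cc(-c2nn(CC#N)cc2-c2ccnc(-c3ccc(N(C)C)cc3)c2)c1` likewise gives only a limit in this assay, > 100000 nM. Compound 3 `COc1cc(C)cc(-c2nn(CC#N)cc2-c2ccc(-c3cccc(C(C)=O)c3)nc2)c1` also gives only a limit in this assay, > 100000 nM. Compound 2 therefore has no number of its own; it stands at the limit together with the other two measured compounds, as the limit of > 100000 nM in this assay, at which 3 of the 3 values shown sit, shows. Within the data shown here, no pair of measured compounds differing in one place is present, so the size of any single structural change has not yet been observed in this assay.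

Compound 4 `Cc1cc(O)cc(-c2nn(CC#N)cc2-c2ccnc(-c3ccc(N(C)C)cc3)c2)c1` differs from compound 2 by hydrogen in place of methyl on an oxygen on an aromatic ring. Among the measured compounds shown here, with every measured value sitting at the limit and no measured step to lean on, the step is expected to be none beyond the scatter, written as a step that the limit leaves unreadable from compound 2 to compound 4. Compound 4 is estimated at 150000 nM in this assay, within a range from 50000 nM to 500000 nM, with a further limit report the likelier outcome.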

Compound 4, concentration lethal to 50% of the cells: 84100 nM
The estimate for compound 4 lay 1.8-fold (0.25 log units) above the measured number; measured number inside the range.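

Compound 4 is the only compound shown with a number of its own in this assay: compound 4 gives 84100 nM. Among these compounds, this makes the oxygen on the aromatic ring the one place so far where a change has yielded a readable value, with methoxy to hydroxy giving an at least 1.1-fold lower number from compound 2 to compound 4 (0.07 log units; that floor lies within the scatter). That is a floor and not a measured size, and compound 2 remains a limit, so the real distance between the two compounds cannot be read: the limit of > 100000 nM in this assay, at which 3 of the 4 values shown sit.

As far as these compounds go, whether the same methoxy to hydroxy change on compound 1 or compound 3 also gives a number remains open. Also open, from the compounds shown here alone, is how an amine or a carboxylic acid at this place would read, and whether a longer chain on the oxygen returns the series to the limit.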